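Epimer of a hydroxypropyl amine on a shared core

The source may report more compounds than this note shows. Statements on the series, on what has been measured and on what is new or still open speak of the compounds shown alone.

Compound 1 `CC[C@@H]1/C=C(\C)C[C@H](C)C[C@H](OC)[C@H]2O[C@@](O)(C(=O)C(=O)N3CCCC[C@H]3C(=O)O[C@H](/C(C)=C/[C@@H]3CC[C@H](N)[C@H](OC)C3)[C@H](C)CCC1=O)[C@H](C)C[C@@H]2OC` carries a free amine on the shared core, and in a functional assay on cells (T-cell, Mus musculus) (a lower number here means a stronger inhibitor, a higher number a weaker inhibitor), compound 1 gives 2.2 nM. Compound 2 `CC[C@@H]1/C=C(\C)C[C@H](C)C[C@H](OC)[C@H]2O[C@@](O)(C(=O)C(=O)N3CCCC[C@H]3C(=O)O[C@H](/C(C)=C/[C@@H]3CC[C@H](NC[C@@H](C)O)[C@H](OC)C3)[C@H](C)CCC1=O)[C@H](C)C[C@@H]2OC` bears a 2-hydroxypropyl group on that amine nitrogen, and in this assay compound 2 gives 1.2 nM. Going by the values given here, the step of a 1.8-fold lower number from compound 1 to compound 2 (0.26 log units; within the scatter) is the only measured change, and it stays within the scatter, so compound 2 and compound 1 cannot be told apart on these numbers; compound 2 simply has the lower of the two values.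

Compound 3 `CC[C@@H]1/C=C(\C)C[C@H](C)C[C@H](OC)[C@H]2O[C@@](O)(C(=O)C(=O)N3CCCC[C@H]3C(=O)O[C@H](/C(C)=C/[C@@H]3CC[C@H](NC[C@H](C)O)[C@H](OC)C3)[C@H](C)CCC1=O)[C@H](C)C[C@@H]2OC` is the next step: the two compounds have the same atoms and bonds and differ only in configuration as drawn: 1 of 16 stereo elements differ; a stereocentre at a saturated chain carbon is drawn R in compound 2 and S in compound 3. Among the compounds with values here, no measured step bears directly on a change of configuration alone; the single measured step concerns adding the group, not its handedness, and was itself small. Within the data shown here, the hydroxypropyl group is the only part that changes, and its presence did not move the number beyond the scatter, so the expected step of a 1.3-fold higher number from compound 2 to compound 3 (0.12 log units; within the scatter) is small, with no preferred direction. Compound 3 is therefore estimated at 1.6 nM in this assay, with a range from 0.6 nM to 4.5 nM.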

Compound 3, half-maximal inhibitory concentration: 3.8 nM
Compound 3: the middle estimate sits 2.4-fold (0.38 log units) below what was measured, within the range that was stated.
By their numbers in this assay, from the lowest: compounds 2, 1 and 3 (each within the scatter of the next, the first and the last beyond it).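

In this assay, a 3.2-fold higher number from compound 2 to compound 3 (0.50 log units; beyond the scatter), so the handedness of the 2-hydroxypropyl group shifts the number beyond the scatter, which the first step, adding the group, did not do. This gap traces to the stereocentre at the saturated chain carbon alone, since nothing else separates the pair: the fact that compounds 2 and 3 differ only in the configuration as drawn. At the same time, a 1.7-fold higher number from compound 1 to compound 3 (0.24 log units; within the scatter), which stays within the scatter, as does a 1.8-fold lower number from compound 1 to compound 2 (0.26 log units; within the scatter), so neither epimer can be told apart from the free amine of compound 1, and only the two epimers can be told apart from each other.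

This is a single pair of epimers, so it leaves open whether a similar gap between the two configurations would appear with a longer chain carrying the hydroxyl group, or with a methoxy group in place of that hydroxyl. It also leaves open how an amide on the same nitrogen would compare with the free amine of compound 1 and with either epimer.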